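A Mirror Image Tested for Cytotoxicity

The source may report more compounds than this note shows. Statements on the series, on what has been measured and on what is new or still open speak of the compounds shown alone.

In an ADME assay on MRC5 cells (Homo sapiens) for cytotoxicity (on this read-out lower numbers stand for stronger inhibition and higher numbers for weaker inhibition), compound 1 `O=[N+]([O-])c1cn2c(n1)S(=O)(=O)CC(Oc1ccc(C(F)(F)F)cn1)C2` gives 46000 nM. Compound 2 `O=[N+]([O-])c1cn2c(n1)[S@+]([O-])C[C@H](OCc1ccc(OC(F)(F)F)cc1)C2` gives > 64000 nM, which is a limit of the assay and not a number. This places compound 2 at the limit of > 64000 nM in this assay, at which 1 of the 2 values shown sits. Compound 3 `O=[N+]([O-])c1cn2c(n1)[S@@+]([O-])C[C@@H](OCc1ccc(OC(F)(F)F)cc1)C2` is its mirror image: the two compounds have the same atoms and bonds and differ only in configuration as drawn: 2 of 2 stereo elements differ (all stereocentres are inverted: mirror images); a stereocentre at a sulfur is drawn R in compound 2 and S in compound 3; a stereocentre at a saturated ring carbon is drawn R in compound 2 and S in compound 3. Going by the values given here, no pair of mirror images has been measured here, so the expectation is modest: no shift beyond the usual scatter, in either direction. The expected change, a number no higher from compound 2 to compound 3 (the limit leaves the size open), is therefore small. For compound 3, the estimated value is 64000 nM, with an expected range from 32000 nM to 128000 nM.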

Compound 3, half-maximal inhibitory concentration: > 64000 nM
Compound 3: only a limit was reported (the forecaster's own chance of this, stated with the estimate: 65%); the middle value sits exactly at the limit.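

Going by these compounds alone, compound 2 and compound 3 each give only a limit of the assay and not a number, so no step between them can be read. From the compounds shown here alone, whether these two mirror images truly differ, and by how much, stays open.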